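A Methyl Group Added to the Side Chain of Compound 1

A few compounds are considered here, and "the series" means these few. Any claim that something is new, unique, unknown or untested is made for them only; others in the source may bear on it.

Compound 1 `O=C1C(=O)N(CCOc2ccccc2)c2ccc(OC(F)(F)F)cc21`: 91%
Compound 2 `COc1ccc(CN2C(=O)C(O)(C[N+](=O)[O-])c3cc(OC(F)(F)F)ccc32)cc1`: 75%

Of the compounds shown here, two have been measured in an assay on isolated protein for positive allosteric modulation of muscarinic acetylcholine receptor M5 (Homo sapiens); a lower number here means a smaller maximal response, a higher number a larger maximal response. Compound 1 gives 91%, the higher of the two numbers. Compound 2 gives 75% in this assay , and the gap between the two lies beyond the usual scatter. The two compounds differ in several places at once, so nothing can be read from the pair about any single change.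

Compound 3 `Cc1cccc(OCCN2C(=O)C(=O)c3cc(OC(F)(F)F)ccc32)c1` differs from compound 1 in one place only: methyl in place of hydrogen on an aromatic carbon. Among the measured compounds shown here, no measured pair shares this change, so there is no step to lean on. A methyl in place of hydrogen on an aromatic carbon is a small addition, and the largest response of compound 3 is therefore expected to stay near that of compound 1, with a step of a number 3 percentage points lower from compound 1 to compound 3 (within the scatter) that is expected to fall within the scatter. For compound 3 the estimate is 88%, between 72% and 104%.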

Compound 3, largest response reached (Emax), in percent of the reference or control that the assay uses: 91%
Beside the measured number, compound 3's estimate is 3 percentage points below it; the range from low to high includes it.
By their numbers in this assay, from the lowest: compound 2; then compounds 1 and 3 (each within the scatter of the next).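

Changing phenoxy to 3-methylphenoxy gives no change at the digits printed from compound 1 to compound 3 (within the scatter) in this assay. Among the compounds shown here, compounds 1 and 2 differ in several places at once, whereas this pair differs in one, so it is the first to tie a reading to a single change. It shows that this position on the aromatic ring of the side chain can carry a methyl without a shift in the largest response beyond the scatter, and no measurement is available here to explain this result.

A single methyl at a single place says little about how far this tolerance extends. From the compounds shown here alone, whether the response would hold with an amine, a carboxylic acid or a longer chain such as propyl at this position, or with a methyl elsewhere on the ring, remains open.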